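Benzyloxy series: esters at the chain carbon, gastric inhibition

The compounds below may be only part of what the source reports. "The series", "measured", "known", "first", "only" and "open" are said of these compounds alone.

Measured compounds: compound 1 `Cc1nc2c(OCc3ccccc3)cccn2c1CCC#N`, 20%; compound 2 `Cc1nc2c(OCc3ccccc3)cccn2c1CO`, 80%; compound 3 `COC(=O)Cc1c(C)nc2c(OCc3ccccc3)cccn12`, 16%.

In a functional assay on the whole organism (stomach) for inhibition, with Canis familiaris (Canis lupus familiaris) as the target, at a dose of 5 mg/kg by the intravenous route (on this read-out higher numbers stand for a stronger effect at the one dose given and lower numbers for a weaker effect), compound 3 stands lowest of the three; compound 1 lies nearest, a number 4 percentage points lower from compound 1 to compound 3 (within the scatter), and compound 2 furthest, a number 64 percentage points lower from compound 2 to compound 3 (beyond the scatter). Compound 4 `Cc1nc2c(OCc3ccccc3)cccn2c1COC(=O)c1cccnc1` differs from compound 3 by ((pyridin-3-yl)carbonyl)oxy in place of methoxycarbonyl on a saturated chain carbon bound to an aromatic carbon. The step bearing on it is a number 64 percentage points lower from compound 2 to compound 3 (beyond the scatter), which shows that replacing hydroxy at this chain carbon with a carbonyl-bearing group cost a large part of the read-out, while a number 4 percentage points lower from compound 1 to compound 3 (within the scatter) was within the scatter. Compound 4 keeps a carbonyl at that carbon but through an oxygen link, so a moderate rise above compound 3 is expected in this assay, a number 29 percentage points higher from compound 3 to compound 4 (beyond the scatter), with wide uncertainty. The estimate for compound 4 is 45%, range 15% to 80%.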

Compound 4, a percentage reported as inhibition, in the whole organism at one dose (the size of the read-out at that dose, not a potency): 88%
Beside the measured number, compound 4's estimate is 43 percentage points below it; the whole stated range lies below it.
By their numbers in this assay, from the lowest: compounds 3 and 1 (each within the scatter of the next); then compounds 2 and 4 (each within the scatter of the next).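

In this assay, the step of a number 72 percentage points higher from compound 3 to compound 4 (beyond the scatter) and the step of a number 68 percentage points higher from compound 1 to compound 4 (beyond the scatter) show that a carbonyl-bearing group on this chain carbon does not always lose the read-out: the ((pyridin-3-yl)carbonyl)oxy ester keeps it, while the methoxycarbonyl of compound 3 does not. Placing (pyridin-3-yl)carbonyl on the hydroxy oxygen gives a number 8 percentage points higher from compound 2 to compound 4 (within the scatter), so a free hydroxy hydrogen is not needed for a high read-out at this dose. Nothing available explains these differences.

Open, from the compounds shown here alone, is how a plain benzoyl ester, an acetyl ester or an amine on this chain carbon would read in this assay, which would separate the pyridine ring from the oxygen link.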